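Urea aryl variation on the shared core: compound 3

The source may report more compounds than this note shows. Statements on the series, on what has been measured and on what is new or still open speak of the compounds shown alone.

Compound 2 `COC(=O)c1cc(=O)c2cc(NC(=O)NCc3ccccc3)ccc2[nH]1` is the reference point in this set. In a functional assay on SUP-B15 cells (Homo sapiens) for antiproliferative activity, with a stated time of 72 h (on this read-out lower numbers stand for an effect already at smaller amounts and higher numbers for an effect only at larger amounts of compound), compound 2 gives only a limit, > 19500 nM (the limit of > 19500 nM in this assay, at which 1 of the 2 values shown sits). For the measured compounds named here, compound 1 `COC(=O)c1cc(=O)c2cc(NC(=O)Nc3ccc(F)c(Cl)c3)ccc2[nH]1` is the only other measured member. In this assay compound 1 also gives only a limit, > 12600 nM (the limit of > 12600 nM in this assay, at which 1 of the 2 values shown sits). The step that the two limits leave unreadable from compound 1 to compound 2 is therefore not readable in size or direction. Compound 3 `COC(=O)c1cc(=O)c2cc(NC(=O)Nc3ccc4c(c3)CCC4)ccc2[nH]1` differs from compound 2 by 2,3-dihydro-1H-inden-5-yl in place of benzyl on an amide-type nitrogen. Going by the values given here, no measured step in this assay bears a readable size, so the only guidance is that both known ureas on that nitrogen, with 3-chloro-4-fluorophenyl or benzyl, stay at the limits. For a step that the limit leaves unreadable from compound 2 to compound 3 no step beyond the scatter is expected. Compound 3 is estimated at 20000 nM, with a range from 5000 nM to 60000 nM, and most probably this assay again reports only a limit for compound 3.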

Compound 3, half-maximal effective concentration: > 24100 nM
Compound 3 was reported as a limit (the forecaster's own chance of this, stated with the estimate: 70%); middle value at least 1.2-fold (0.08 log units) from the limit.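

In this assay compound 3 gives only a limit, > 24100 nM. For the compounds shown here, no step among compound 1, compound 2 and compound 3 can therefore be read in size or direction. These compounds leave open whether any group on that amide-type nitrogen gives a readable value in this assay.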